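The source may hold more compounds than are shown below. What is called first, only, known or untested is meant among the compounds shown, and "the series" means these compounds.

Two members of the series have numbers in an ADME assay on J774 cells (Mus musculus) for cytotoxicity, read by MTT assay, with a stated time of 48 h, tested at 100 ug/mL; on this read-out lower numbers stand for a stronger effect and higher numbers for a weaker effect at the one concentration tested. Compound 1 `O=C(N/N=C/c1ccc(Br)cc1)c1cnccn1` gives 100% in this assay, the highest of the two numbers shown. Compound 2 `N#Cc1ccccc1/C=N/NC(=O)c1cnccn1` gives 75% in this assay, a number that sits beyond the scatter below that of compound 1. Compound 3 `CN(C)c1ccc(/C=N/NC(=O)c2cnccn2)cc1` has no number in this assay yet. Its change from compound 1 is dimethylamino in place of bromo on an aromatic carbon. Among the measured compounds shown here, no measured pair shows a comparable change, so the expected step of a number 12 percentage points lower from compound 1 to compound 3 (beyond the scatter) is small, a slight move downward that need not clear the scatter. For compound 3 the estimate is 88%, with a range from 62% to 100%.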

Compound 3, a percentage reported as activity, at one concentration (the size of the read-out at that concentration, not a potency): 87%
Estimate against measurement, compound 3: 1 percentage points above, and the stated range covers the measured number.
By their numbers in this assay, from the lowest: compound 2; then compound 3; then compound 1.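

The series now has its first pair differing in one place: dimethylamino in place of bromo, on an aromatic carbon para to a large group, gives a number 13 percentage points lower from compound 1 to compound 3 (beyond the scatter) in this assay. The read-out at this position therefore depends on the group it carries, though the step is modest. No available measurement bears on the reason for this step.

With one pair at this position, the loss of bromo and the arrival of dimethylamino cannot be separated. As far as these compounds go, the outcome with a primary amine or a carboxylic acid at the same place remains open.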